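Hydrogen for Methyl on an Aromatic Oxygen, Seen Twice

The source may hold more compounds than are shown below. What is called first, only, known or untested is meant among the compounds shown, and "the series" means these compounds.

Four compounds share one core and differ at two places. Compound 1 `COc1cc2oc(-c3ccccc3)cc(=O)c2c(O)c1OCCCCN1CCN(C)CC1` carries a methyl on an oxygen on an aromatic ring, and in a functional assay on A549 cells (Homo sapiens) for antiproliferative activity, read by MTT assay, with a stated time of 48 h (a higher number here means a weaker inhibitor, a lower number a stronger inhibitor), compound 1 gives 32000 nM. Compound 2 `CN1CCN(CCCCOc2c(O)cc3oc(-c4ccccc4)cc(=O)c3c2O)CC1` differs from compound 1 in one way: hydrogen in place of methyl on an oxygen on an aromatic ring. For compound 2 this assay reports only a limit, > 100000 nM. As far as these compounds go, the step is an at least 3.1-fold higher number from compound 1 to compound 2 (0.49 log units; beyond the scatter), and it runs into the limit of the assay (the limit of > 100000 nM in this assay, at which 1 of the 3 values shown sits), so its true size is unknown.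

Compound 3 `COc1cc2oc(-c3ccccc3)cc(=O)c2c(O)c1OCCCN1CCCC1` differs from compound 1 at the other place: pyrrolidin-1-yl in place of (4-methylpiperazin-1-yl)methyl on a saturated chain carbon, three bonds along the chain from an oxygen on an aromatic ring. In this assay compound 3 gives 6000 nM, a step of a 5.3-fold lower number from compound 1 to compound 3 (0.73 log units; beyond the scatter).

Compound 4 `O=c1cc(-c2ccccc2)oc2cc(O)c(OCCCN3CCCC3)c(O)c12` has not yet been measured. It differs from compound 3 in one way: hydrogen in place of methyl on an oxygen on an aromatic ring. This is the same change as from compound 1 to compound 2, at the same place. Compound 4 is therefore expected to be weaker than compound 3 by a step of roughly a 5.0-fold higher number from compound 3 to compound 4 (0.70 log units; beyond the scatter), resting on the earlier change an at least 3.1-fold higher number from compound 1 to compound 2 (0.49 log units; beyond the scatter). In this assay compound 4 is estimated at 30000 nM, with a likely range from 10000 nM to 100000 nM.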

Compound 4, half-maximal inhibitory concentration: > 100000 nM
Compound 4 gave a limit, no number (the forecaster's own chance of this, stated with the estimate: 20%); middle value at least 3.3-fold (0.52 log units) from the limit.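

In this assay, the change from methoxy to hydroxy again gives a higher number, meaning a weaker inhibitor, with a step of an at least 16-fold higher number from compound 3 to compound 4 (1.22 log units; beyond the scatter). The result for compound 4, > 100000 nM, is a limit and not a number. The change therefore carries its direction from the core of compound 1 to that of compound 3, in the only two pairs shown, but this does not show that it carries its size: the same change on two cores in this assay, an at least 3.1-fold higher number (0.49 log units; beyond the scatter) from compound 1 to compound 2 and an at least 16-fold higher number (1.22 log units; beyond the scatter) from compound 3 to compound 4; the limit leaves it open whether they differ

As far as these compounds go, the step between compound 2 and compound 4, which would show how the two side chains compare without the methyl, cannot be read because both compounds sit at the limit: the limit of > 100000 nM in this assay, at which 2 of the 4 values shown sit. Also open is whether the same step would appear with an ethyl group in place of the methyl on that oxygen, or with a morpholine in place of the pyrrolidin-1-yl group at the end of the chain.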